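This account rests on a few compounds, and the source may have more. Where it says the series, first, only, none or still open, it means among the compounds named here.

Measured so far in a functional assay on OVCAR-5 cells (Homo sapiens) for cytotoxicity, read by sulforhodamine B assay, with a stated time of 48 h, tested at 0.1 uM; on this read-out higher numbers stand for a weaker effect at the one concentration tested and lower numbers for a stronger effect:
compound 1 `COc1cc(-c2cc(/C=C/C(=O)c3ccc(N)cc3)[nH]n2)cc(OC)c1OC` — 103%
compound 2 `COc1ccc(-c2cc(/C=C/C(=O)c3ccc(N)cc3)[nH]n2)cc1OC` — 95%
compound 3 `COc1ccc(-c2cc(/C=C/C(=O)c3cc(OC)c(OC)c(OC)c3)[nH]n2)cc1OC` — 92%

Compound 1 stands highest of the three numbers, though only its gap to compound 3 lies beyond the scatter; the gap to compound 2 does not. Within the data shown here, the one single-point step recorded is a number 8 percentage points lower from compound 1 to compound 2 (within the scatter), a swap of hydrogen in place of methoxy on an aromatic carbon, and it stays within the scatter. Among the measured compounds shown here, compound 3 differs from compound 1 in more than one place, so no single step is drawn from that pair; what can be said is that compound 3, which carries a methoxy-bearing ring on the carbonyl carbon, gives the lowest number of the three.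

Compound 4 `COc1ccc(C(=O)/C=C/c2cc(-c3cc(OC)c(OC)c(OC)c3)n[nH]2)cc1OC` is reached from compound 1 by 3,4-dimethoxyphenyl in place of 4-aminophenyl on a carbonyl carbon. For the measured compounds named here, no measured step touches the ring on the carbonyl carbon, so the expectation rests on the general picture: all three values so far sit near the top of the scale, and the only recorded step is flat. A small step down, at most on the edge of the scatter, is expected; the step of a number 8 percentage points lower from compound 1 to compound 4 (within the scatter) is the estimate. Compound 4 is therefore expected to give about 95% in this assay, within 82% to 106%.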

Compound 4, a percentage reported as activity, at one concentration (the size of the read-out at that concentration, not a potency): 88%
The estimate for compound 4 lay 7 percentage points above the measured number; measured number inside the range.
By their numbers in this assay, from the lowest: compounds 4, 3, 2 and 1 (each within the scatter of the next, the first and the last beyond it).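

In this assay, among these compounds, replacing 4-aminophenyl with 3,4-dimethoxyphenyl on a carbonyl carbon gives a number 15 percentage points lower from compound 1 to compound 4 (beyond the scatter), the first single-place step to lie beyond the scatter, whereas the earlier swap of hydrogen for methoxy gave a number 8 percentage points lower from compound 1 to compound 2 (within the scatter). Among the compounds shown here, the read-out therefore does respond to a change at this place, though only modestly: compound 4 gives 88%, which is the size of the effect at one concentration and not a potency, and the single change both removes 4-aminophenyl, with 1 hydrogen-bond donor, and introduces 3,4-dimethoxyphenyl, with 2 hydrogen-bond acceptors. Nothing available accounts for the step.

Still open, on these data alone, is whether the step follows from the loss of the amine or the arrival of the methoxy groups, a question that a plain phenyl on the same carbonyl carbon would help to separate. Also open, as far as these compounds go, is whether a carboxylic acid or a longer chain on that ring would move the read-out further than compound 4 does.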